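This account rests on a few compounds, and the source may have more. Where it says the series, first, only, none or still open, it means among the compounds named here.

Among the measured compounds shown here, compound 2 `CCCC[C@@H](/C=C\[C@@H]1OC(=O)C=C[C@@H]1OC(C)=O)OC(C)=O` gives in a functional assay on BC1 cells (Homo sapiens) for cytotoxicity, read by sulforhodamine B assay, with a stated time of 72 h (on this read-out lower numbers stand for an effect already at smaller amounts and higher numbers for an effect only at larger amounts of compound), a value of 1 ug/mL, the smaller of the two numbers known, yet compound 1 `CCCC[C@@H](/C=C\[C@@H]1OC(=O)C=C[C@@H]1O)OC(C)=O`, which gives 2 ug/mL, sits within the scatter of it: a 2.0-fold lower number from compound 1 to compound 2 (0.30 log units; within the scatter). Compound 3 `CCCC[C@H](O)/C=C\[C@@H]1OC(=O)C=C[C@@H]1OC(C)=O` differs from compound 2 by hydrogen in place of acetyl on an oxygen on a saturated carbon. For the measured compounds named here, the one measured step concerns the other oxygen and was small; no measured step bears directly on this change. Compound 3 is therefore expected to stay close to compound 2, with an estimated 2.0-fold higher number from compound 2 to compound 3 (0.30 log units; within the scatter). In this assay compound 3 is estimated at 2 ug/mL, between 0.7 ug/mL and 6 ug/mL.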

Compound 3, concentration for half-maximal effect: 2.5 ug/mL
Compound 3: middle estimate off by 1.3-fold (0.10 log units), on the low side; the range from low to high includes it.
By their numbers in this assay, from the lowest: compounds 2, 1 and 3 (each within the scatter of the next, the first and the last beyond it).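

In this assay, the change from acetoxy to hydroxy on this oxygen on a saturated carbon gives a 2.5-fold higher number from compound 2 to compound 3 (0.40 log units; beyond the scatter) and so registers as a modest loss. Among the compounds shown here, the only earlier step, on the other oxygen, gave a 2.0-fold lower number from compound 1 to compound 2 (0.30 log units; within the scatter) and did not separate the compounds. Nothing at hand explains this difference between the two oxygens.
The compounds shown leave open how a longer chain or an amine on this oxygen would read, and whether the shared core keeps its effect with hydroxy on both oxygens.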